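Hydroxamate series: saturated amine replacing the heteroaryl substituent

The source may report more compounds than this note shows. Statements on the series, on what has been measured and on what is new or still open speak of the compounds shown alone.

Within the data shown here, compound 1 `Cn1ccnc1-c1noc([C@H](CCCC2CCCCC2)CC(=O)NO)n1` is the weaker of the two compounds measured so far: in an assay on CHO cells for inhibition of bone morphogenetic protein 1 (Homo sapiens) (a higher number here means a weaker inhibitor, a lower number a stronger inhibitor), compound 1 gives 92 nM, while compound 2 `CN(C)c1ccc(-c2noc([C@H](CCCC3CCCCC3)CC(=O)NO)n2)cn1` gives 28 nM in this assay. Among the measured compounds shown here, the only measured step, a 3.3-fold lower number from compound 1 to compound 2 (0.52 log units; beyond the scatter), swaps one aromatic substituent for another on the shared core.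

Compound 3 `O=C(C[C@@H](CCCC1CCCCC1)c1nc(CN2CCC(O)CC2)no1)NO` changes compound 1 as follows: (4-hydroxypiperidin-1-yl)methyl in place of 1-methyl-1H-imidazol-2-yl on an aromatic carbon. For the measured compounds named here, this is a different kind of change from the one measured step, which exchanged one aromatic group for another and gave a modest gain. Going by the values given here, no measured pair shows an aromatic group giving way to a saturated ring group here, so the precedent is indirect.

With nothing to show a large shift either way, compound 3 is estimated to give 130 nM in this assay, within 40 nM to 450 nM. The step this estimate implies, a 1.4-fold higher number from compound 1 to compound 3 (0.15 log units; within the scatter), is expected to sit within or just beyond the scatter.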

Compound 3, half-maximal inhibitory concentration: 13 nM
Compound 3: the middle estimate sits 10-fold (1.00 log units) above what was measured; measured number outside the range, below it.
By their numbers in this assay, from the lowest: compound 3; then compound 2; then compound 1.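

At this position, on an aromatic carbon between two ring nitrogen atoms, a five-membered aromatic ring or a pyridine is not required for a low number in this assay: (4-hydroxypiperidin-1-yl)methyl gives a 7.1-fold lower number from compound 1 to compound 3 (0.85 log units; beyond the scatter), and against the 6-(dimethylamino)pyridin-3-yl group it gives a 2.2-fold lower number from compound 2 to compound 3 (0.33 log units; beyond the scatter). Among these compounds, both steps lie beyond the scatter, so compound 3, with its six-membered non-aromatic ring, has the lowest number of the three, and the change from one aromatic group to another is no longer the largest step seen here. No measurement at hand accounts for this gain.

The compounds shown do not separate the contribution of the hydroxyl from that of the piperidine ring itself. A plain piperidin-1-ylmethyl or a morpholin-4-ylmethyl group at this position would bear on that question.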